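Thiophene to iodine at one aromatic carbon of a nucleoside

The compounds below may be only part of what the source reports. "The series", "measured", "known", "first", "only" and "open" are said of these compounds alone.

Compound 3 `Cc1ncnc2c1c(-c1ccsc1)cn2[C@@H]1O[C@H](CO)[C@@H](O)[C@H]1O` is the only one of the three measured compounds that yields a number in a functional assay on HCT-116 cells (Homo sapiens), read by MTT assay, with a stated time of 72 h; a higher number here means a weaker inhibitor, a lower number a stronger inhibitor: compound 3 gives 460 nM. Compound 2 `Cc1ncnc2c1c(-c1ccoc1)cn2[C@@H]1O[C@H](CO)[C@@H](O)[C@H]1O` sits at the limit of this assay, at > 20000 nM. Compound 1 `COc1ncnc2c1c(I)cn2[C@@H]1O[C@H](CO)[C@@H](O)[C@H]1O` sits at the same limit, at > 20000 nM. Among the measured compounds shown here, the single measured step between compounds differing in one place is an at least 43-fold lower number from compound 2 to compound 3 (1.63 log units; beyond the scatter), which shows how strongly the group on that aromatic carbon sways the result. Compound 4 `Cc1ncnc2c1c(I)cn2[C@@H]1O[C@H](CO)[C@@H](O)[C@H]1O` differs from compound 3 in one place: iodo in place of thiophen-3-yl on an aromatic carbon. For the measured compounds named here, no measured step covers this exact change. Compound 1 carries iodo at the same place, though with a different group elsewhere, and gives only a limit. The account therefore expects a large loss in potency, a step of a 26-fold higher number from compound 3 to compound 4 (1.42 log units; beyond the scatter), with a real chance that only a limit is reported. Compound 4 is estimated at 12000 nM, within a range from 2000 nM to 60000 nM.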

Compound 4, half-maximal inhibitory concentration: 4720 nM
Compound 4: middle estimate off by 2.5-fold (0.41 log units), on the high side; measured number inside the range.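

In this assay, iodo in place of thiophen-3-yl gives a 10-fold higher number from compound 3 to compound 4 (1.01 log units; beyond the scatter), so the thiophene outperforms the single iodine atom, yet the iodo compound still reaches a measurable number. Iodo in place of furan-3-yl gives an at least 4.2-fold lower number from compound 2 to compound 4 (0.62 log units; beyond the scatter), so with the methyl group held constant, the three groups at this aromatic carbon rank thiophen-3-yl, then iodo, then furan-3-yl, and having a five-membered aromatic ring there does not by itself give the better result. The other site matters too, as methyl in place of methoxy gives an at least 4.2-fold lower number from compound 1 to compound 4 (0.62 log units; beyond the scatter); this step and the one from the furan are bounds only, because each starts from a limit of the assay: the limit of > 20000 nM in this assay, at which 2 of the 4 values shown sit.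

As far as these compounds go, what an amine or a phenyl ring would give at this carbon remains open. So does whether methyl in place of methoxy has a similar effect when thiophen-3-yl replaces iodo.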